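The source may report more compounds than this note shows. Statements on the series, on what has been measured and on what is new or still open speak of the compounds shown alone.

Compound 1 `CC(C)=CCC/C(C)=C/CC/C(C)=C/CC[C@]1(C)CCc2c(C)c(OC(=O)c3ccc(C(=O)O)cc3C(=O)O)c(C)c(C)c2O1` is the fully methylated head of the series, and in a functional assay on cells (+SA cell, Mus musculus) for cytotoxicity, read by MTT assay, with a stated time of 24 h (on this read-out higher numbers stand for weaker inhibition and lower numbers for stronger inhibition), compound 1 gives 1500 nM. Compound 2 `CC(C)=CCC/C(C)=C/CC/C(C)=C/CC[C@]1(C)CCc2cc(OC(=O)c3ccc(C(=O)O)cc3C(=O)O)c(C)c(C)c2O1` differs from it by hydrogen in place of methyl on an aromatic carbon; in this assay compound 2 gives 620 nM, and the result is a 2.4-fold lower number from compound 1 to compound 2 (0.38 log units; beyond the scatter). Compound 3 `CC(C)=CCC/C(C)=C/CC/C(C)=C/CC[C@]1(C)CCc2cc(OC(=O)/C=C\C(=O)O)c(C)c(C)c2O1` keeps the core of compound 2 but exchanges the acyl part of the ester; in this assay compound 3 gives 2300 nM, so that a 3.7-fold higher number from compound 2 to compound 3 (0.57 log units; beyond the scatter). The values of compound 3 and compound 1 lie within the scatter of each other and are not ordered here.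

Compound 4 `CC(C)=CCC/C(C)=C/CC/C(C)=C/CC[C@]1(C)CCc2cc(OC(=O)/C=C\C(=O)O)cc(C)c2O1` has not been measured. Relative to compound 3 it shows (hydrogen in place of methyl on an aromatic carbon). This is the same kind of change as that made from compound 1 to compound 2, but not the same change: there the place was ortho to a fused ring, ortho to a large group, meta to a fused ring, meta to a methyl group and para to a methyl group, whereas here it is ortho to a ((2-carboxyethenyl)carbonyl)oxy group, ortho to a methyl group, meta to a fused ring and para to a fused ring. The difference between the two cores of compound 3 and compound 1 is not broken down here. A single earlier instance of the change, at a different place, is all that the expectation can rest on, namely compound 1 and compound 2 through a 2.4-fold lower number from compound 1 to compound 2 (0.38 log units; beyond the scatter), so it is held loose. In this assay compound 4 is expected to give 1400 nM, within a range from 600 nM to 3500 nM. The implied step a 1.6-fold lower number from compound 3 to compound 4 (0.22 log units; within the scatter) is estimated to be modest and in the same direction as the earlier one.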

Compound 4, half-maximal inhibitory concentration: 870 nM
Compound 4: the middle estimate sits 1.6-fold (0.21 log units) above what was measured, within the range that was stated.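

In this assay, hydrogen in place of methyl on an aromatic carbon gives a 2.6-fold lower number from compound 3 to compound 4 (0.42 log units; beyond the scatter), so the change again goes with a lower number, this time on a core carrying the 2-carboxyethenyl ester rather than the 2,4-dicarboxyphenyl ester. Set beside the earlier instance, the two steps agree in direction and show no difference in size, although the place on the ring and the acyl part of the ester both differ: the same change on two cores in this assay, a 2.4-fold lower number (0.38 log units; beyond the scatter) from compound 1 to compound 2 and a 2.6-fold lower number (0.42 log units; beyond the scatter) from compound 3 to compound 4, 1.1-fold (0.04 log units) apart, within the scatter of two such steps This is agreement between only two pairs, and since place and acyl part differ together, it cannot separate their contributions, nor does it show that the step would stay the same on further cores or at every aromatic carbon of this ring.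

Still open, as far as these compounds go, is how the two changes combine, namely the size of the step for the same place on the two ester types, and what a removal of both methyl groups from the ring of compound 4 would give. Also open, from the compounds shown here alone, is whether the step depends on hydrogen itself, which an ethyl group or a chlorine at the same place could test, and whether it survives an amide in place of the ester link.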